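Replacing the chloro group of compound 3

This account rests on a few compounds, and the source may have more. Where it says the series, first, only, none or still open, it means among the compounds named here.

In an ADME assay on microsomes from liver (Rattus norvegicus) for metabolic stability, read by LC-MS, using NADPH, with stated times of 6 min and 10 min, tested at 0.5 uM (a lower number here means that less of the compound is left, a higher number that more of the compound is left), compound 1 (`CC(=O)N1CCN(c2cc(C)cc(-c3cc(Cl)c4c(N)ncnn34)c2)C(=O)C1(C)C`) gives 100% and compound 2 (`COc1ccc(-c2cc(Cl)c3c(N)ncnn23)cc1N1CCN(C(C)=O)C(C)(C)C1=O`) gives 91%. Compound 3 (`CC(=O)N1CCN(c2cc(-c3cc(Cl)c4c(N)ncnn34)ccc2Cl)C(=O)C1(C)C`) gives 52%, the lowest of the three numbers, and its gaps to both of the others lie beyond the usual scatter.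

Compound 4 (`CC(=O)N1CCN(c2cc(-c3cc(Cl)c4c(N)ncnn34)ccc2C(C)O)C(=O)C1(C)C`) differs from compound 3 in one place: 1-hydroxyethyl in place of chloro on an aromatic carbon, ortho to a large group and para to a large group (1-hydroxyethyl in place of chloro on an aromatic carbon).

Among the compounds with values here, one measured step bears on this change, and it also involves the chloro group. It is a number 39 percentage points lower from compound 2 to compound 3 (beyond the scatter), a large step with chloro in place of methoxy. Read in reverse, it shows that a compound without the chloro group can keep a much higher number. However, 1-hydroxyethyl is not methoxy, and no measured compound carries it.

A rise smaller than that drop is therefore expected, and the expected change is a number 18 percentage points higher from compound 3 to compound 4 (beyond the scatter). Compound 4 is estimated at 70%, within a range from 45% to 92%.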

Compound 4, percent of the compound remaining: 100%
The estimate for compound 4 lay 30 percentage points below the measured number, outside the stated range (above it).
By their numbers in this assay, from the lowest: compound 3; then compounds 2, 1 and 4 (each within the scatter of the next).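

In this assay the swap of chloro for 1-hydroxyethyl on this aromatic carbon gives a number 48 percentage points higher from compound 3 to compound 4 (beyond the scatter) and so shows that the low number of compound 3 does not carry over to this larger group. The swap of methoxy for 1-hydroxyethyl gives a number 9 percentage points higher from compound 2 to compound 4 (within the scatter) and so separates these two groups no further than repeated measurements would, leaving chloro as the one group of the three with a low number among these compounds. No measurement at hand explains why the number changes with the group at this position.

The compounds shown leave open whether the hydroxyl of 1-hydroxyethyl is needed for the high number or whether a plain ethyl group would do the same. As far as these compounds go, how an amine or a carboxylic acid on this aromatic carbon would read is equally open.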